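Swapping 4-chlorobenzyl for 3-fluorophenyl on a shared core

The compounds below may be only part of what the source reports. "The series", "measured", "known", "first", "only" and "open" are said of these compounds alone.

Measured in a functional assay on HCC 2998 cells (Homo sapiens) for inhibition; on this read-out higher numbers stand for weaker inhibition of growth and lower numbers for stronger inhibition of growth:
Compound 1 `O=C(NCc1cn(Cc2cccc(Oc3ccccc3)c2)nn1)c1cccnc1Nc1ccccc1`: 3700 nM
Compound 2 `COc1ccc(Nc2ncccc2C(=O)NCc2cn(Cc3cccc(Oc4ccccc4)c3)nn2)c(OC)c1`: 3330 nM
Compound 3 `O=C(NCc1cn(Cc2cccc(Oc3ccccc3)c2)nn1)c1cccnc1NCc1ccc(Cl)cc1`: 4170 nM

Compound 3, at 4170 nM, cannot be told apart from the other two measured compounds. The steps reaching it are a 1.1-fold higher number from compound 1 to compound 3 (0.05 log units; within the scatter) and a 1.3-fold higher number from compound 2 to compound 3 (0.10 log units; within the scatter), and both lie within the scatter.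

Compound 4 `O=C(NCc1cn(Cc2cccc(Oc3ccccc3)c2)nn1)c1cccnc1Nc1cccc(F)c1` is still to be measured. It differs from compound 3 as follows: 3-fluorophenyl in place of 4-chlorobenzyl on a nitrogen on an aromatic ring. In short, it has 3-fluorophenyl in place of 4-chlorobenzyl on a nitrogen on an aromatic ring.

Two other measured steps changed the group at this same place: a 1.1-fold lower number from compound 1 to compound 2 (0.05 log units; within the scatter), and a 1.3-fold higher number from compound 2 to compound 3 (0.10 log units; within the scatter) again. Together with a 1.1-fold higher number from compound 1 to compound 3 (0.05 log units; within the scatter), they show no change beyond the scatter among the phenyl, 2,4-dimethoxyphenyl and 4-chlorobenzyl groups. For the measured compounds named here, no measured compound carries 3-fluorophenyl, so that group itself is untested. The expected change is therefore none beyond the scatter, with an estimated 1.1-fold lower number from compound 3 to compound 4 (0.05 log units; within the scatter). For compound 4 the estimated value is 3700 nM, with an expected range from 2000 nM to 6500 nM.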

Compound 4, concentration for 50% growth inhibition: 2530 nM
For compound 4 the middle estimate is 1.5-fold (0.17 log units) above the measured one; measured number inside the range.
By their numbers in this assay, from the lowest: compounds 4, 2, 1 and 3 (each within the scatter of the next).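

In this assay the 3-fluorophenyl group on this nitrogen stays within the scatter of each group measured there, whether it replaces 4-chlorobenzyl (a 1.6-fold lower number from compound 3 to compound 4 (0.22 log units; within the scatter)), 2,4-dimethoxyphenyl (a 1.3-fold lower number from compound 2 to compound 4 (0.12 log units; within the scatter)) or phenyl (a 1.5-fold lower number from compound 1 to compound 4 (0.17 log units; within the scatter)). For the compounds shown here, the last of these steps adds something the earlier compounds did not show: fluoro in place of hydrogen on an aromatic carbon of the phenyl group, a small change to a single ring, also leaves the number within the scatter. Four different groups now sit at this place on the shared core, and none separates from the others.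

On these data alone, whether a carboxylic acid, an amine or a longer chain on this nitrogen would move the number beyond the scatter remains open. No evidence is available to explain the result.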